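The source may report more compounds than this note shows. Statements on the series, on what has been measured and on what is new or still open speak of the compounds shown alone.

Of the compounds shown here, three have been measured in a physicochemical assay for lipophilicity, read by HPLC, in phosphate buffer, measured as chromatographic lipophilicity, at pH 7.4; on this read-out higher numbers stand for higher lipophilicity and lower numbers for lower lipophilicity. Compound 1 `COc1ccc2c(OCC(=O)Nc3cc(C)cc(C)c3)cc(C)nc2c1` gives 5.59, compound 2 `Cc1cc(C)cc(NC(=O)COc2cc(C)nc3ccc(F)cc23)c1` gives 5.79, and compound 3 `COc1cccc(NC(=O)COc2cc(C)nc3ccc(OC)cc23)c1` gives 4.49, the lowest of the three, lying beyond the scatter under both compound 1 and compound 2. Compound 4 `COc1ccc2nc(C)cc(OCC(=O)Nc3ccccn3)c2c1` has not yet been measured in this assay. It differs from compound 3 in one place: pyridin-2-yl in place of 3-methoxyphenyl on an amide-type nitrogen. Among the compounds with values here, no measured pair in this set shows this change, so nothing here fixes its size. The author expects a downward step from compound 3 to compound 4 of about a number 1.19 log units lower from compound 3 to compound 4 (beyond the scatter), beyond the scatter. Compound 4 is therefore estimated to give 3.3 in this assay, with a likely range from 2.6 to 4.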

Compound 4, distribution coefficient: 3.49
Estimate against measurement, compound 4: 0.19 log units below; the measured number falls inside the stated range.
By their numbers in this assay, from the lowest: compound 4; then compound 3; then compounds 1 and 2 (each within the scatter of the next).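

In this assay, within the data shown here, the change from 3-methoxyphenyl to pyridin-2-yl on the amide-type nitrogen gives the first measured step at this position (a number 1.00 log units lower from compound 3 to compound 4 (beyond the scatter)). This shows that replacing the group on this nitrogen can move the read-out by more than the scatter while the rest of the molecule stays the same. Nothing available explains the size of this step. The compounds shown leave open how an unsubstituted phenyl or a pyridin-3-yl on this nitrogen would read. The loss of the methoxy group and the entry of the ring nitrogen therefore cannot be separated.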